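Replacing a Sulfonyl Piperazine With a Small Primary Amine

This account rests on a few compounds, and the source may have more. Where it says the series, first, only, none or still open, it means among the compounds named here.

Compound 2 `CS(=O)(=O)N1CCN(CCCOc2ccc([C@H]3CC[C@]4(CC3)OOC3(O4)C4CC5CC(C4)CC3C5)cc2)CC1` is one of two measured compounds here. In a physicochemical assay for solubility, read by nephelometry, measured as kinetic solubility, with a stated time of 30 min (on this read-out higher numbers stand for higher solubility and lower numbers for lower solubility), compound 2 gives < 1.6 ug/mL, which is a limit of the assay, not a number (the limit of < 1.6 ug/mL in this assay, at which 1 of the 2 values shown sits). Compound 1 `c1cc([C@H]2CC[C@]3(CC2)OOC2(O3)C3CC4CC(C3)CC2C4)ccc1OCCC1CCNCC1` gives > 100 ug/mL in this assay, again only a limit (the limit of > 100 ug/mL in this assay, at which 1 of the 2 values shown sits). Compound 3 `CC(C)(N)CCOc1ccc([C@H]2CC[C@]3(CC2)OOC2(O3)C3CC4CC(C3)CC2C4)cc1` differs from compound 2 by 1-amino-1-methylethyl in place of (4-(methylsulfonyl)piperazin-1-yl)methyl on a saturated chain carbon, two bonds along the chain from an oxygen on an aromatic ring. The measured step of an at least 62-fold lower number from compound 1 to compound 2 (1.79 log units; beyond the scatter) brought in the very group that now leaves, so it bears directly on this change. Reversing it, the expected step is an at least 62-fold higher number from compound 2 to compound 3 (1.79 log units; beyond the scatter), a large rise. Compound 3 is estimated at 100 ug/mL, within 20 ug/mL to 200 ug/mL.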

Compound 3, solubility: 50 ug/mL
Compound 3: middle estimate off by 2.0-fold (0.30 log units), on the high side; low and high end bracket the measured number.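

In this assay, the shared core does not by itself fix the reading: at this place on the chain, the change to 1-amino-1-methylethyl gives an at least 31-fold higher number from compound 2 to compound 3 (1.49 log units; beyond the scatter). Set against piperidin-4-yl, the same group gives an at least 2.0-fold lower number from compound 1 to compound 3 (0.30 log units; that floor lies within the scatter), so these two groups cannot be ranked. Compound 1 gives a limit of the assay, not a number: the limit of > 100 ug/mL in this assay, at which 1 of the 3 values shown sits.

As far as these compounds go, whether a carboxylic acid at this place would read like compound 3 stays open. So does the reading for an unbranched aminoethyl group.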